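A Side Chain Change at the Limit of Tolerance

The compounds below may be only part of what the source reports. "The series", "measured", "known", "first", "only" and "open" are said of these compounds alone.

Measured in a functional assay on HEL cells (Homo sapiens) for cytotoxicity; a lower number here means that less compound is tolerated, a higher number that more compound is tolerated:
Compound 1 `C=CCCCc1cc2cn([C@H]3C[C@H](O)[C@@H](CO)O3)c(=O)nc2o1`: > 200000 nM (a limit)
Compound 2 `C=CCCCCCCc1cc2cn([C@H]3C[C@H](O)[C@@H](CO)O3)c(=O)nc2o1`: > 200000 nM (a limit)

Compound 2 stands at > 200000 nM in this assay, which is a limit of the assay and not a number. Compound 1 and compound 2 share one reading, (the limit of > 200000 nM in this assay, at which 2 of the 2 values shown sit), so neither has a numerical value.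

Compound 3 `C#CCCCCc1cc2cn([C@H]3C[C@H](O)[C@@H](CO)O3)c(=O)nc2o1` differs from compound 2 as follows: ethynyl in place of but-3-en-1-yl on a saturated chain carbon, four bonds along the chain from an aromatic carbon. In words, it carries ethynyl in place of but-3-en-1-yl on a saturated chain carbon, four bonds along the chain from an aromatic carbon.

Going by the values given here, only one measured step bears on this change: a step that the two limits leave unreadable from compound 1 to compound 2. It swaps vinyl for pent-4-en-1-yl on the same side chain, and it has no readable size. With compound 2 at the limit of > 200000 nM, no step beyond the scatter is expected in this assay, and compound 3 is expected to stay near that limit. The expected step is a number no higher from compound 2 to compound 3 (the limit leaves the size open). For compound 3 the estimated value is 200000 nM, with an expected range of 80000 nM to 400000 nM.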

Compound 3, half-maximal cytotoxic concentration: > 200000 nM
Compound 3: no number, only a limit; the forecaster's own chance of this, stated with the estimate: 85%; the middle value lies on the limit itself.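

In this assay compound 3 gives > 200000 nM, a limit of the assay and not a number. Going by these compounds alone, no step among compound 1, compound 2 and compound 3 can be read, as all three share one reading: the limit of > 200000 nM in this assay, at which 3 of the 3 values shown sit. On these data alone, whether their side chains differ at all in this assay, and at what concentration any of the three becomes cytotoxic, stays open.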